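This account rests on a few compounds, and the source may have more. Where it says the series, first, only, none or still open, it means among the compounds named here.

Measured compounds in a functional assay on the whole organism (Tail, strain ICR) with Mus musculus as the target, in the tail flick test, with a stated time of 120 min, at a dose of 25 umol/kg by the oral route; a higher number here means a stronger effect of the compound at the dose given, a lower number a weaker effect: compound 1 `C[C@@H](O)[C@H](NC(=O)CN(c1nc(Cl)nc2[nH]cnc12)C1CC1)C(=O)O` gives 37.6%; compound 2 `C[C@H](NC(=O)CN(c1ncnc2c1ncn2C1CCCCO1)C1CC1)C(=O)OCc1ccccc1` gives 25.3%; compound 3 `CC[C@H](C)[C@H](NC(=O)CN(c1nc(Cl)nc2[nH]cnc12)C1CC1)C(=O)O` gives 21.4%.

Compound 2 stands second highest of the three numbers in this assay; its value and that of compound 3 lie within the scatter of each other, while compound 1 lies beyond the scatter above it. Compound 4 `O=C(CN(c1ncnc2c1ncn2C1CCCCO1)C1CC1)N[C@@H](CC(=O)OCc1ccccc1)C(=O)OCc1ccccc1` differs from compound 2 by benzyloxycarbonyl in place of hydrogen on a saturated chain carbon, two bonds along the chain from an amide-type nitrogen and a carbonyl carbon. Within the data shown here, the only measured step, a number 16.2 percentage points lower from compound 1 to compound 3 (beyond the scatter), concerns a different change, ethyl in place of hydroxy, and contains no benzyloxycarbonyl group, so it offers no direct guide here. Among the measured compounds shown here, with no precedent at this place, no shift beyond the scatter is expected, and the step of a number 3.3 percentage points lower from compound 2 to compound 4 (within the scatter) is estimated as small. Compound 4 is therefore expected at 22%, in the range 8% to 38%.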

Compound 4, a percentage reported as activity, at one dose (the size of the read-out at that dose, not a potency): 7.82%
For compound 4 the middle estimate is 14.2 percentage points above the measured one, outside the stated range (below it).
By their numbers in this assay, from the lowest: compound 4; then compounds 3 and 2 (each within the scatter of the next); then compound 1.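

In this assay, placing benzyloxycarbonyl on a saturated chain carbon, two bonds along the chain from an amide-type nitrogen and a carbonyl carbon, gives a number 17.5 percentage points lower from compound 2 to compound 4 (beyond the scatter). This is the first change at this place among these compounds, and it shows that the read-out is sensitive to what this carbon carries. Nothing measured here accounts for the step.

From the compounds shown here alone, whether a carboxylic acid or an amine at this place would give a similar step remains open. So does whether a plain longer chain would lower the read-out as well.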